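This account rests on a few compounds, and the source may have more. Where it says the series, first, only, none or still open, it means among the compounds named here.

Working notes on the series. Compound 1 `COc1ccc(C(=O)/C=C/c2cc(-c3ccc(OC)c(OC)c3)n3nc(-c4ccccc4)cc3n2)cc1OC` and compound 2 `COc1ccc(/C=C/C(=O)c2cc(-c3ccc(OC)c(OC)c3)n3nc(-c4ccccc4)cc3n2)cc1` share one core and differ in the group hung on it. In a functional assay on DU-145 cells (Homo sapiens) for antiproliferative activity, read by MTT assay, with a stated time of 24 h (on this read-out lower numbers stand for stronger inhibition and higher numbers for weaker inhibition), compound 1 gives 7200 nM. In this assay, going by the values given here, compound 2 gives 14900 nM, the higher of the two numbers; the gap between them is beyond the usual scatter, and with only two measured compounds nothing more can be read from the pair.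

Compound 3 `COc1ccc(-c2cc(/C=C/C(=O)c3ccc(C)c(C)c3)nc3cc(-c4ccccc4)nn23)cc1OC` has not been measured in this assay. It differs from compound 2 by 2-((3,4-dimethylphenyl)carbonyl)ethenyl in place of (2-(4-methoxyphenyl)ethenyl)carbonyl on an aromatic carbon. In compound 3 the carbonyl sits within the entering 2-((3,4-dimethylphenyl)carbonyl)ethenyl group, and one hydrogen-bond acceptor is lost with the leaving group.

Among the compounds with values here, no measured step of the same kind exists, so the expectation rests on the two values alone. A step toward lower numbers is expected, of modest size, at about the edge of the scatter, because compound 1 with 7200 nM shows that a lower number than that of compound 2 is reachable on this core. The step from compound 2 to compound 3 is estimated at a 1.9-fold lower number from compound 2 to compound 3 (0.27 log units; within the scatter). Compound 3 is estimated at 8000 nM, with a range from 3000 nM to 20000 nM.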

Compound 3, half-maximal inhibitory concentration: 12100 nM
Estimate against measurement, compound 3: 1.5-fold (0.18 log units) below; measured number inside the range.
By their numbers in this assay, from the lowest: compounds 1, 3 and 2 (each within the scatter of the next, the first and the last beyond it).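

Going by these compounds alone, compound 3 gives the first reading of where the carbonyl may stand in the side group on this aromatic carbon: 2-((3,4-dimethylphenyl)carbonyl)ethenyl in place of (2-(4-methoxyphenyl)ethenyl)carbonyl gives a 1.2-fold lower number from compound 2 to compound 3 (0.09 log units; within the scatter) in this assay, so this exchange, which also changes the substituents on the outer phenyl ring, is not resolved on this read-out. Within the data shown here, it also gives the first reading of the outer ring with the carbonyl orientation held fixed: 3,4-dimethylphenyl in place of 3,4-dimethoxyphenyl on a carbonyl carbon gives a 1.7-fold higher number from compound 1 to compound 3 (0.23 log units; within the scatter), and in this assay the two substituted rings cannot be told apart. No measured property of these compounds bears on either step.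

The compounds shown leave open whether a phenyl ring carrying a dimethylamino group or a carboxylic acid, in place of 3,4-dimethylphenyl on the carbonyl carbon, would give a step beyond the scatter. They also leave open how 4-methoxyphenyl on that carbonyl carbon would read, which would separate the carbonyl orientation from the change of ring substituents.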